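Stripping the sulfonamide nitrogen substituent from compound 2

A few compounds are considered here, and "the series" means these few. Any claim that something is new, unique, unknown or untested is made for them only; others in the source may bear on it.

Compound 1 `O=S(=O)(Nc1ncccn1)c1ccc(Nc2nncc3ccccc23)cc1` gives 29 nM
Compound 2 `Cc1cc(NS(=O)(=O)c2ccc(Nc3nncc4ccccc34)cc2)no1` gives 23 nM

Among the measured compounds shown here, in a functional assay on HT-29 cells (Homo sapiens) for antiproliferative activity, read by sulforhodamine B assay, with a stated time of 72 h (a higher number here means a weaker inhibitor, a lower number a stronger inhibitor), compound 2 stands within the scatter of compound 1, the only other measured compound, and the step between them is a 1.3-fold lower number from compound 1 to compound 2 (0.10 log units; within the scatter). Compound 3 `NS(=O)(=O)c1ccc(Nc2nncc3ccccc23)cc1` carries a different change, (hydrogen in place of 5-methyl-1,2-oxazol-3-yl on a sulfonamide nitrogen), that is, hydrogen in place of 5-methyl-1,2-oxazol-3-yl on a sulfonamide nitrogen. For the measured compounds named here, the one measured step only exchanges one ring group for another, so it gives weak guidance for a change that leaves no ring group at all. A modest move to a higher number in this assay is expected, with much uncertainty. The estimated change is a 2.2-fold higher number from compound 2 to compound 3 (0.34 log units; beyond the scatter). For compound 3 the estimated value is 50 nM, with an expected range of 10 nM to 300 nM.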

Compound 3, half-maximal inhibitory concentration: 12 nM
For compound 3 the middle estimate is 4.2-fold (0.62 log units) above the measured one; the range from low to high includes it.
By their numbers in this assay, from the lowest: compounds 3, 2 and 1 (each within the scatter of the next, the first and the last beyond it).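

In this assay, the sulfonamide nitrogen needs no ring group to hold this level of activity: with hydrogen in place of 5-methyl-1,2-oxazol-3-yl the step is a 1.9-fold lower number from compound 2 to compound 3 (0.28 log units; within the scatter), and with hydrogen in place of pyrimidin-2-yl it is a 2.4-fold lower number from compound 1 to compound 3 (0.38 log units; beyond the scatter). Only the second of these steps lies beyond the scatter, so the gain over a ring group is modest and is seen against pyrimidin-2-yl alone. Nothing available explains this result. The compounds shown leave open how a small methyl or acetyl group on this nitrogen would read. They also leave open whether a carboxylic acid could stand in place of the whole sulfonamide.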